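This account rests on a few compounds, and the source may have more. Where it says the series, first, only, none or still open, it means among the compounds named here.

Of the compounds shown here, three of this small series have so far been measured in a physicochemical assay for lipophilicity, at pH 3; a higher number here means a more lipophilic compound, a lower number a more polar compound. Compound 1 `Cc1cccc2c(NCc3ccco3)nc(NC(C)C)nc12` gives 1.57. Compound 2 `Cc1cccc2nc(NC(C)C)nc(NCc3ccco3)c12`, built from the same atoms joined differently, gives 2.44; the difference between the two cores is not broken down here. Compound 3 `COc1cccc2c(NCc3ccco3)nc(NC(C)C)nc12` gives 2.99.

Among the measured compounds, compound 3 stands highest, compound 2 second highest, and compound 1 lowest, each of the gaps lying beyond the usual scatter of this assay.

Among the measured compounds shown here, the one structural change measured in both directions of comparison is methoxy in place of methyl on an aromatic carbon. It made a step of a number 1.42 log units higher from compound 1 to compound 3 (beyond the scatter).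

Compound 4 `COc1cccc2nc(NC(C)C)nc(NCc3ccco3)c12` is not yet measured. It differs from compound 2 by methoxy in place of methyl on an aromatic carbon. The place of the change in compound 4 matches the place of the change in compound 3 word for word, so it is the same change on the core of compound 2. The two cores themselves differ, and how that difference bears on this change is not known from these compounds.

He expects the change from compound 2 to compound 4 to go in the same direction as the earlier one, and to be of a broadly similar size, because the earlier step was a number 1.42 log units higher from compound 1 to compound 3 (beyond the scatter) and compound 2 starts at 2.44; his estimate is a step of a number 1.26 log units higher from compound 2 to compound 4 (beyond the scatter) in this assay, but the single prior example makes the size uncertain. He therefore estimates compound 4 at 3.7, with a range from 3 to 4.3.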

Compound 4, distribution coefficient: 2.53
Compound 4: middle estimate off by 1.17 log units, on the high side; the measured number lies below the stated range.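

In this assay, methoxy in place of methyl on an aromatic carbon gives a number 0.09 log units higher from compound 2 to compound 4 (within the scatter), whereas the same change on the other core gives a number 1.42 log units higher from compound 1 to compound 3 (beyond the scatter). The large step seen on the core of compound 1 therefore did not carry over to the core of compound 2, so in this series the size of the step cannot be taken from one core to the other, even when the change stands at the matching place. With only one pair on each core, this shows that the outcome can depend on the core but does not give a general rule for the series, and nothing shown here explains why the two cores differ in their response.

The compounds shown leave open whether this split between the cores is particular to methoxy or would also appear with another group at the same place, such as an ethoxy group, a chlorine atom or an amine. They also leave open whether the step on each core would hold with a longer chain in place of the isopropyl amine or with another ring in place of the furan.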